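This account rests on a few compounds, and the source may have more. Where it says the series, first, only, none or still open, it means among the compounds named here.

Among the measured compounds shown here, in a functional assay on SK-BR-3 cells (Homo sapiens) for antiproliferative activity, with a stated time of 48 h (a higher number here means that more compound is needed for the effect, a lower number that less compound is needed), compound 2 `CN(C)c1ccc(NC(=O)CCCCCCC(=O)NO)cc1` gives 4200 nM, the higher of the two numbers measured so far, while compound 1 `O=C(CCCCCCC(=O)Nc1ccc(I)cc1)NO` gives 1100 nM. Compound 3 `O=C(CCCCCCC(=O)Nc1ccc([N+](=O)[O-])cc1)NO` differs from compound 2 at a single place, (nitro in place of dimethylamino on an aromatic carbon), so nitro takes the place of dimethylamino on an aromatic carbon. For the measured compounds named here, only one measured step bears on this change: a 3.8-fold higher number from compound 1 to compound 2 (0.58 log units; beyond the scatter), a modest step beyond the scatter, in which dimethylamino replaced iodo at that same place. Dimethylamino therefore sits in the compound with the higher number, and removing it may bring the value back towards that of compound 1. One step is thin evidence, and nitro itself has not yet been tested, so the range must stay wide. The expected change is a 2.6-fold lower number from compound 2 to compound 3 (0.42 log units; beyond the scatter), a modest move towards a lower number. For compound 3 the estimated value is 1600 nM, with an expected range from 600 nM to 4200 nM.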

Compound 3, half-maximal effective concentration: 58000 nM
For compound 3 the middle estimate is 36-fold (1.56 log units) below the measured one, outside the stated range (above it).
By their numbers in this assay, from the lowest: compound 1; then compound 2; then compound 3.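

On an aromatic carbon para to a large group, exchanging one group for another with the same count of heavy atoms can move the result far: a 14-fold higher number from compound 2 to compound 3 (1.14 log units; beyond the scatter) is a large step in this assay and far exceeds the modest step seen earlier. The gap to the iodo group is wider still, since a 53-fold higher number from compound 1 to compound 3 (1.72 log units; beyond the scatter) is also large and places the nitro compound highest of the three. This position therefore tolerates some groups much better than others, and the heavy-atom count alone does not set the number for dimethylamino and nitro.

No measurement shown here explains why nitro stands so far from the other two groups. As far as these compounds go, three groups give an order but no rule, so it remains open where a methoxy group, a chlorine atom, a primary amine or a carboxylic acid at this place would fall.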